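The source may hold more compounds than are shown below. What is called first, only, known or untested is meant among the compounds shown, and "the series" means these compounds.

Measured so far:
compound 1, `CCOc1ccccc1N1CCN(CCCNc2ncccc2C(=O)N(C)C)CC1`: 7.94 nM
compound 2, `CN(C)C(=O)c1cccnc1NCCCN1CCN(c2ccccc2OCC(C)(C)C)CC1`: 50.1 nM

In a functional assay on aorta for antagonist activity at Alpha-1D adrenergic receptor (Rattus norvegicus) (a lower number here means tighter binding, a higher number weaker binding), compound 2 gives the higher of the two numbers; its nearest neighbour is compound 1, and a 6.3-fold higher number from compound 1 to compound 2 (0.80 log units; beyond the scatter). Compound 3, `CN(C)C(=O)c1cccnc1NCCCN1CCN(c2ccccc2C(F)(F)F)CC1`, is not yet measured. Change: trifluoromethyl in place of neopentyloxy on an aromatic carbon. Among the compounds with values here, only the step from compound 1 to compound 2 bears on this, having varied the same group, and it was modest. Within the data shown here, the entering group is smaller than the neopentyloxy it replaces, but no measured step covers loss of the oxygen, so the number is expected to fall part of the way back toward compound 1: a 2.5-fold lower number from compound 2 to compound 3 (0.40 log units; beyond the scatter). Compound 3 is estimated at 20 nM, range 6 nM to 63 nM.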

Compound 3, dissociation constant: 316 nM
Compound 3: the middle estimate sits 16-fold (1.20 log units) below what was measured, outside the stated range (above it).
By their numbers in this assay, from the lowest: compound 1; then compound 2; then compound 3.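

In this assay, replacing neopentyloxy with trifluoromethyl on this aromatic carbon gives a 6.3-fold higher number from compound 2 to compound 3 (0.80 log units; beyond the scatter), and replacing ethoxy with trifluoromethyl gives a 40-fold higher number from compound 1 to compound 3 (1.60 log units; beyond the scatter). Heavy-atom count alone does not order these three compounds: neopentyloxy, the largest group, gives a middle number, while both groups bound through oxygen give lower numbers than trifluoromethyl. Nothing shown explains this difference.

On these data alone, whether the oxygen itself matters remains open. A propyl chain, a methoxy group or a single chlorine on this carbon would separate the contribution of the oxygen from that of the group beyond it.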